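Methyl on the amide nitrogen of compound 3

The source may hold more compounds than are shown below. What is called first, only, known or untested is meant among the compounds shown, and "the series" means these compounds.

Compound 1, `CS(=O)(=O)Nc1ccc(-c2ccc3c(O)cccc3c2)cc1`, gives 75% in an assay for binding affinity to 17-beta-hydroxysteroid dehydrogenase type 2 (Homo sapiens), with a stated time of 20 min, tested at 1 uM; on this read-out lower numbers stand for less inhibition and higher numbers for more inhibition at the one concentration tested (going by the name of the read-out). Compound 2, `CC(=O)Nc1cccc(-c2ccc(CO)cc2)c1`, is reported only as a limit, < 10%, in this assay. Compound 3, `O=C(Nc1cccc(-c2ccc(CO)cc2)c1)c1ccccc1`, is likewise reported only as a limit, < 10%, in this assay.

Compound 3 therefore stands at the limit of < 10% in this assay, at which 2 of the 3 values shown sit, not at a number. For the measured compounds named here, the one step that reaches it, a step that the two limits leave unreadable from compound 2 to compound 3, cannot be read because both ends are limits. Compound 4, `CN(C(=O)c1ccccc1)c1cccc(-c2ccc(CO)cc2)c1`, differs from compound 3 by methyl in place of hydrogen on an amide-type nitrogen. No measured step touches this amide hydrogen, so nothing shown points to a change beyond the scatter in this assay, and compound 4 is expected to remain at the limit, giving an estimated 7% (from 0% to 22%). The step that the limit leaves unreadable from compound 3 to compound 4 is thus expected to be essentially none.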

Compound 4, a percentage reported as inhibition, at one concentration (the size of the read-out at that concentration, not a potency): < 10%
Compound 4 ended at the assay's limit; the forecaster's own chance of this, stated with the estimate: 70%; the middle value lies beyond the limit too.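

Compound 3 and compound 4 are both reported only as limits in this assay, so the step between them cannot be read. The compounds shown leave open whether methyl in place of the amide hydrogen changes inhibition at all.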